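One Change on the Carbonyl Carbon of Compound 1

A few compounds are considered here, and "the series" means these few. Any claim that something is new, unique, unknown or untested is made for them only; others in the source may bear on it.

Measured in an assay on CHO cells for displacement of a labelled ligand from adenosine receptor A1 (Homo sapiens), read by scintillation counting, with a stated time of 120 min, tested at 1 uM; a lower number here means less inhibition, a higher number more inhibition at the concentration tested (going by the name of the read-out):
Compound 1, `Cc1nc(NC(=O)c2ccccc2)c2nn(-c3ccccc3)cc2n1`: 30%
Compound 2, `COc1ccc(-n2cc3nc(Cc4ccccc4)nc(N)c3n2)cc1`: 40%

Compound 1 and compound 2 lie within the usual scatter of each other in this assay, so the two are not told apart; their inhibition in this assay is level, and neither number is set apart from the other.

Compound 3, `Cc1nc(NC(=O)NCc2ccccc2)c2nn(-c3ccccc3)cc2n1`, keeps the core of compound 1 and alters one group: benzylamino in place of phenyl on a carbonyl carbon. Within the data shown here, the two measured compounds differ in several places at once, so there is no measured step of this kind to lean on. With nothing showing that this change moves the read-out, the step from compound 1 to compound 3 is expected to stay within the scatter, estimated as no change at the digits printed from compound 1 to compound 3 (within the scatter). Compound 3 is therefore expected to give about 30% in this assay, with a plausible range from 10% to 55%.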

Compound 3, a percentage reported as inhibition, at one concentration (the size of the read-out at that concentration, not a potency): 26%
Compound 3: middle estimate off by 4 percentage points, on the high side; measured number inside the range.
By their numbers in this assay, from the lowest: compounds 3, 1 and 2 (each within the scatter of the next, the first and the last beyond it).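

In this assay, among these compounds, benzylamino in place of phenyl on a carbonyl carbon gives a number 4 percentage points lower from compound 1 to compound 3 (within the scatter), the first measured step at this place. The entering group brings a nitrogen and a hydrogen-bond donor that phenyl lacks, yet the read-out does not tell the two compounds apart, so this particular change leaves inhibition level at the concentration tested. No available measurement bears on why the two compounds sit level.

As far as these compounds go, it remains open whether a different group on the same carbonyl carbon, such as a longer phenethylamino chain, a cyclohexyl ring or a carboxylic acid, would separate from compound 1. From the compounds shown here alone, a reading at one concentration also gives the size of the inhibition there rather than a potency, so any difference in potency between compound 1 and compound 3 remains open too.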